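The source may report more compounds than this note shows. Statements on the series, on what has been measured and on what is new or still open speak of the compounds shown alone.

Measured compounds in an ADME assay on Vero cells (Chlorocebus sabaeus) for cytotoxicity; on this read-out higher numbers stand for lower toxicity in this test and lower numbers for higher toxicity in this test:
- compound 1 `Fc1ccc(-c2nn3c(NC4CCCC4)cccc3c2-c2ccc(NC3CCCC3)nc2)cc1`: "not determined" (no result reported)
- compound 2 `Fc1ccc(-c2nn3c(NC4CCCC4)cccc3c2-c2cccnc2F)cc1`: "not determined" (no result reported)
- compound 3 `Nc1nccc(-c2c(-c3ccc(F)cc3)nn3c(NC4CCCC4)cccc23)n1`: 46000 nM

Compound 2 stands without a number in this assay, and compound 1 likewise has none; only compound 3 gives a value, 46000 nM, so nothing in the series can be placed against compound 2 by number. The change to compound 4 `Fc1ccc(-c2nn3c(NC4CCCC4)cccc3c2-c2cccnc2)cc1` is hydrogen in place of fluoro on an aromatic carbon. Among the measured compounds shown here, no step between measured compounds exists here, so the size of this step in this assay is unknown; a change within the scatter is expected, with no direction claimed. The cytotoxic concentration of compound 4 is estimated at 40000 nM, in the range 12000 nM to 120000 nM, resting only on the value of compound 3, 46000 nM.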

Compound 4, half-maximal cytotoxic concentration: > 40000 nM
Compound 4: no number, only a limit (the forecaster's own chance of this, stated with the estimate: 30%); the middle value sits exactly at the limit.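

In this assay, among the compounds shown here, compound 4 gives only a limit, > 40000 nM, so no step to it from compound 2 or compound 3 can be read. Going by these compounds, whether going from 2-fluoropyridin-3-yl to pyridin-3-yl changes this read-out stays open.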